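This account rests on a few compounds, and the source may have more. Where it says the series, first, only, none or still open, it means among the compounds named here.

Measured so far in an assay on isolated protein for inhibition of cathepsin S (Homo sapiens); a higher number here means a weaker inhibitor, a lower number a stronger inhibitor:
- compound 1, `Cn1c(=O)n(C2CCN(CCCn3nc(-c4ccc(Cl)c(Cl)c4)c4c3CCN(S(C)(=O)=O)C4)CC2)c2ccccc21`: 10 nM
- compound 2, `CC(=O)N1CCc2c(c(-c3ccc(C(F)(F)F)cc3)nn2CC(O)CN2CCC(c3coc4cc(F)ccc34)CC2)C1`: 360 nM
- compound 3, `COc1ccc2[nH]cc(C3CCN(CC(O)Cn4nc(-c5ccc(C(F)(F)F)cc5)c5c4CCN(S(C)(=O)=O)C5)CC3)c2c1`: 29 nM

Compound 3 stands second highest of the three numbers in this assay. Its nearest neighbour is compound 1, whose number is lower by a gap beyond the scatter; the furthest is compound 2, whose number is higher by a gap well beyond the scatter. Among the measured compounds shown here, no pair among the measured compounds differs in only one place, so these gaps carry no single structural lesson.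

Compound 4, `CS(=O)(=O)N1CCc2c(c(-c3ccc(C(F)(F)F)cc3)nn2CC(O)CN2CCC(c3c[nH]c4c(Cl)cccc34)CC2)C1`, has not yet been measured. Relative to compound 3 the change is 7-chloro-1H-indol-3-yl in place of 5-methoxy-1H-indol-3-yl on a saturated ring carbon; the rest of the molecule is kept. For the measured compounds named here, nothing among the measured compounds isolates an exchange of this kind, so no step size can be read off. With a donor retained and an acceptor dropped at the same place on the saturated ring carbon, the expected step in this assay from compound 3 to compound 4 is a small one, toward a weaker inhibitor, possibly within the scatter: a 1.6-fold higher number from compound 3 to compound 4 (0.19 log units; within the scatter). Compound 4 is accordingly estimated at 45 nM in this assay, within a range from 14 nM to 140 nM.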

Compound 4, half-maximal inhibitory concentration: 34 nM
The estimate for compound 4 lay 1.3-fold (0.12 log units) above the measured number; the measured number falls inside the stated range.
By their numbers in this assay, from the lowest: compound 1; then compounds 3 and 4 (each within the scatter of the next); then compound 2.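

In this assay, among the compounds shown here, 7-chloro-1H-indol-3-yl in place of 5-methoxy-1H-indol-3-yl on the saturated ring carbon gives a 1.2-fold higher number from compound 3 to compound 4 (0.07 log units; within the scatter), and this is the only step so far that isolates this position. With a hydrogen-bond donor kept and a hydrogen-bond acceptor dropped, and with a chlorine entering where the methoxy group leaves, compounds 3 and 4 are not separated in this assay, so at this place, three ring bonds from the ring nitrogen, the indole accepts either substituted form. No supporting measurement bears on this result, so it stands without an explanation.

The step exchanges the substituent and its place on the indole together, so the separate contributions of the methoxy group and the chlorine remain unresolved; the plain 1H-indol-3-yl, or an indole with chlorine and methoxy exchanged in place, would separate them. Also open, as far as these compounds go, is whether this result extends beyond neutral substituents, to a carboxylic acid or a primary amine on the indole.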